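The source may report more compounds than this note shows. Statements on the series, on what has been measured and on what is new or still open speak of the compounds shown alone.

Measured so far in an ADME assay on Huh-7 cells (Homo sapiens) for cytotoxicity, read by MTT assay, with a stated time of 4 h, at 37 degrees C; a higher number here means that more compound is tolerated, a lower number that less compound is tolerated:
- compound 1 `COc1ccc(Nc2nc3[nH]c(=O)c(-c4ccc(F)cc4)cc3c(=O)[nH]2)cc1`: 46000 nM
- compound 2 `O=C1Nc2nc(NCc3ccccc3)[nH]c(=O)c2CC1c1c(Cl)cccc1Cl`: 69000 nM

Among the measured compounds shown here, compound 1, at 46000 nM, lies within the usual scatter of compound 2, at 69000 nM, so these two numbers set no order between the compounds. For the measured compounds named here, they differ in more than one place, and no measured pair isolates a single change. The series therefore offers no direct measure of the next step.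

Compound 3 `O=c1[nH]c2nc(Nc3ccccc3)[nH]c(=O)c2cc1-c1ccc(F)cc1` is not yet measured in this assay. It keeps the core of compound 1 and carries hydrogen in place of methoxy on an aromatic carbon, so that 4-methoxyphenyl becomes phenyl and (4-methoxyphenyl)amino becomes anilino: hydrogen in place of methoxy on an aromatic carbon. Going by the values given here, with no measured step to draw on, no direction is favoured, and no change beyond the scatter is expected. Among the compounds with values here, the only guide is the level shared by compound 1 at 46000 nM and compound 2 at 69000 nM. The expected step is a 1.1-fold higher number from compound 1 to compound 3 (0.04 log units; within the scatter). For compound 3 the estimated value is 50000 nM, with an expected range of 22000 nM to 110000 nM.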

Compound 3, half-maximal cytotoxic concentration: 13500 nM
Compound 3: middle estimate off by 3.7-fold (0.57 log units), on the high side, outside the stated range (below it).
By their numbers in this assay, from the lowest: compound 3; then compounds 1 and 2 (each within the scatter of the next).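

In this assay, among the compounds shown here, hydrogen in place of methoxy on an aromatic carbon, para to a large group, gives a 3.4-fold lower number from compound 1 to compound 3 (0.53 log units; beyond the scatter), a modest step beyond the scatter and the first change that can be read alone. It shows that this position is not silent in this assay: with the rest of the structure unchanged, less compound is tolerated with anilino than with (4-methoxyphenyl)amino, so the methoxy group cannot be treated as an interchangeable substituent here. No measurement shown explains the step, and its cause remains unassigned.

Going by these compounds, whether a hydroxy group, a chlorine atom or a longer alkoxy chain such as ethoxy on this aromatic carbon would hold the level of compound 1 or fall to that of compound 3 remains open. Also open, on these data alone, is whether the same exchange of methoxy for hydrogen would give a step of similar size and direction on another core, as this single pair cannot establish a trend across the series.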